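A few compounds are considered here, and "the series" means these few. Any claim that something is new, unique, unknown or untested is made for them only; others in the source may bear on it.

Values in a functional assay on A2780 cells (Homo sapiens) for antiproliferative activity, read by sulforhodamine B assay, with a stated time of 72 h; on this read-out higher numbers stand for weaker inhibition and lower numbers for stronger inhibition:
Compound 1 `O=C(NCc1cccnc1)Nc1ccc(S(=O)(=O)N2CC3(COC3)C2)cc1`: > 2000 nM
Compound 2 `O=C(NCc1cccnc1)Nc1ccc(S(=O)(=O)N2CCCNCC2)cc1`: 594 nM

Compound 1 gives > 2000 nM, which is a limit of the assay. Among the measured compounds shown here, compound 2, at 594 nM, holds the only actual number so far.

Compound 3 `CC1CNCCN(S(=O)(=O)c2ccc(NC(=O)NCc3cccnc3)cc2)C1` carries methyl in place of hydrogen on a saturated ring carbon, two ring bonds from the ring nitrogen and two ring bonds from the ring atom that bears a large group: methyl in place of hydrogen on a saturated ring carbon.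

For the measured compounds named here, only one measured step bears on this: an at least 3.3-fold lower number from compound 1 to compound 2 (0.52 log units; beyond the scatter). It exchanges the whole group on the sulfonyl sulfur and rests on a limit, so it gives no measure of what a single methyl does. No step beyond the scatter is expected in this assay, and no direction can be favoured. The expected step is a 1.0-fold higher number from compound 2 to compound 3 (0.00 log units; within the scatter). For compound 3 the estimated value is 600 nM, with an expected range of 250 nM to 1400 nM.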

Compound 3, half-maximal inhibitory concentration: 99 nM
Compound 3: the middle estimate sits 6.1-fold (0.78 log units) above what was measured, and the stated range ends above it.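

In this assay, methyl on a saturated ring carbon, two ring bonds from the ring nitrogen and two ring bonds from the ring atom that bears a large group, gives a 6.0-fold lower number from compound 2 to compound 3 (0.78 log units; beyond the scatter), so this ring position responds to a single added carbon, which the exchange of the whole group on the sulfonyl sulfur could not show. Measured against compound 1, the step widens to an at least 20-fold lower number from compound 1 to compound 3 (1.30 log units; beyond the scatter). The value of compound 1 is a limit of the assay, not a number: the limit of > 2000 nM in this assay, at which 1 of the 3 values shown sits.

Ethyl or hydroxyl on the same ring carbon remain open, so the compounds shown do not tell whether the lower number is tied to methyl itself. Nor do they tell whether methyl elsewhere on the seven-membered ring would give a step of this size.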